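Pentyl to propyl: from compound 1 to compound 3

A few compounds are considered here, and "the series" means these few. Any claim that something is new, unique, unknown or untested is made for them only; others in the source may bear on it.

Measured so far:
compound 1 `CCCCCNc1nc(N)c2nc(O)n(Cc3ccccc3)c2n1` — 0.1 uM
compound 2 `COc1ccccc1Cn1c(O)nc2c(N)ncnc21` — 10 uM

In a functional assay (spleen, spleen) for activation, with Mus musculus as the target (a lower number here means that less compound is needed, a higher number that more compound is needed for the effect), compound 1 gives 0.1 uM, the lower of the two numbers. Compound 2 gives 10 uM, a difference well beyond the scatter. Compound 3 `CCCNc1nc(N)c2nc(O)n(Cc3ccccc3)c2n1` has not been measured; it differs from compound 1 by hydrogen in place of ethyl on a saturated chain carbon, three bonds along the chain from a nitrogen on an aromatic ring. Going by the values given here, no step between measured compounds covers this change, so the expectation rests on compound 1 alone, whose value of 0.1 uM anchors the series. A modest loss, somewhat beyond the scatter, is expected for the step of a 3.0-fold higher number from compound 1 to compound 3 (0.48 log units; beyond the scatter). Compound 3 is therefore expected at 0.3 uM, with a range from 0.1 uM to 1 uM.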

Compound 3, minimum effective concentration: 0.1 uM
The estimate for compound 3 lay 3.0-fold (0.48 log units) above the measured number; low and high end bracket the measured number.
By their numbers in this assay, from the lowest: compounds 1 and 3 (each within the scatter of the next); then compound 2.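

In this assay, going by these compounds alone, hydrogen in place of ethyl on a saturated chain carbon, three bonds along the chain from a nitrogen on an aromatic ring, gives no change at the digits printed from compound 1 to compound 3 (within the scatter) and this is the first step read at this position. The pentyl chain can thus be cut to propyl with no loss that this read-out separates from the scatter. From the compounds shown here alone, whether a shorter ethyl chain, a longer octyl chain, or a chain ending in an amine or a carboxylic acid would hold the number remains open. Compound 2 differs from compound 1 in more than one place and does not settle this. No available evidence bears on this result.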